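Fluoro for Chloro on the Benzylsulfanyl Arm

The source may report more compounds than this note shows. Statements on the series, on what has been measured and on what is new or still open speak of the compounds shown alone.

Three compounds have been measured in a functional assay on the whole organism (artery, strain albino) with Rattus norvegicus as the target, with a stated time of 120 min, at a dose of 10 mg/kg by the oral route; on this read-out higher numbers stand for more inhibition at the one dose given (going by the name of the read-out) and lower numbers for less inhibition:

compound 1, `CC1=C(C(=O)Nc2ccc(F)cc2)C(c2ccc([N+](=O)[O-])cc2)N=C(SCc2ccccc2)N1`, gives 18%;
compound 2, `CC1=C(C(=O)Nc2ccc(F)cc2)C(c2ccc([N+](=O)[O-])cc2)N=C(SCc2ccccc2Cl)N1`, gives 8.8%;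
compound 3, `CC1=C(C(=O)Nc2ccc(F)cc2)C(c2ccc([N+](=O)[O-])cc2)N=C(SCc2ccc(Cl)cc2)N1`, gives 16%.

Compound 3 stands second highest of the three, with compound 1 nearest and compound 2 furthest, both within the scatter. Compound 4, `CC1=C(C(=O)Nc2ccc(F)cc2)C(c2ccc([N+](=O)[O-])cc2)N=C(SCc2ccc(F)cc2)N1`, carries the change (fluoro in place of chloro on an aromatic carbon). The nearest precedents are the chloro steps a number 9.2 percentage points lower from compound 1 to compound 2 (within the scatter) and a number 2 percentage points lower from compound 1 to compound 3 (within the scatter), and the move a number 7.2 percentage points higher from compound 2 to compound 3 (within the scatter); all lie within the scatter, so no step beyond the scatter is expected in this assay, in either direction. Compound 4 is therefore estimated at 15%, between 5% and 26%, a step of a number 1 percentage points lower from compound 3 to compound 4 (within the scatter) being expected.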

Compound 4, a percentage reported as inhibition, in the whole organism at one dose (the size of the read-out at that dose, not a potency): 17%
Beside the measured number, compound 4's estimate is 2 percentage points below it; measured number inside the range.
By their numbers in this assay, from the lowest: compounds 2, 3, 4 and 1 (each within the scatter of the next).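

In this assay, the step for fluoro in place of chloro on this aromatic carbon, para to a large group, is a number 1 percentage points higher from compound 3 to compound 4 (within the scatter). The other two steps, a number 1 percentage points lower from compound 1 to compound 4 (within the scatter) and a number 8.2 percentage points higher from compound 2 to compound 4 (within the scatter), also stay within the scatter, so neither halogen at this place, nor fluoro against hydrogen, separates these compounds. No measurement bearing on this result is available. Still open, on these data alone, is whether an amine or a carboxylic acid at this place, or a longer chain on the sulfur, would give a step beyond the scatter.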